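The compounds below may be only part of what the source reports. "The series", "measured", "known", "first", "only" and "open" are said of these compounds alone.

Measured compounds:
compound 1 `O=C(Nc1cccc(Oc2nccc(C(F)(F)F)c2Cl)c1)C1CCCN(C(=O)c2cc(C(F)(F)F)cc(C(F)(F)F)c2)C1` gives 0%;
compound 2 `O=C(Nc1ccc(Cl)cc1)C1CCCN(C(=O)c2cc(C(F)(F)F)cc(C(F)(F)F)c2)C1` gives 14%.

Both compounds share one core and were read in an ADME assay on PC-3 cells (Homo sapiens) for cytotoxicity, read by WST assay, tested at 100 uM; on this read-out lower numbers stand for less inhibition and higher numbers for more inhibition at the one concentration tested (going by the name of the read-out). In this assay compound 2 stands highest of the two numbers, with its nearest neighbour compound 1 lying lower by a gap that is beyond the usual scatter; both numbers are nevertheless low.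

Compound 3 `Cn1cnnc1-c1cccc(NC(=O)C2CCCN(C(=O)c3cc(C(F)(F)F)cc(C(F)(F)F)c3)C2)c1` has not yet been measured in this assay. It differs from compound 2 in one place: 3-(4-methyl-4H-1,2,4-triazol-3-yl)phenyl in place of 4-chlorophenyl on an amide-type nitrogen.

Among the compounds with values here, no step between two measured compounds isolates this change, so the expected size of the step rests only on the low numbers seen so far. Compound 3 is expected to remain near the low numbers seen so far, with a number 6 percentage points lower from compound 2 to compound 3 (within the scatter) expected to be small and within the scatter, in either direction. Compound 3 is estimated at 8% in this assay, within a range of 0% to 25%.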

Compound 3, a percentage reported as inhibition, at one concentration (the size of the read-out at that concentration, not a potency): 0%
Beside the measured number, compound 3's estimate is 8 percentage points above it, and the stated range covers the measured number.
By their numbers in this assay, from the lowest: compounds 1 and 3 (each within the scatter of the next); then compound 2.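

In this assay, within the data shown here, placing 3-(4-methyl-4H-1,2,4-triazol-3-yl)phenyl instead of 4-chlorophenyl on the amide-type nitrogen gives a number 14 percentage points lower from compound 2 to compound 3 (beyond the scatter), a first reading of a single change at this position, and a modest one. Putting 4-methyl-4H-1,2,4-triazol-3-yl in place of (3-chloro-4-(trifluoromethyl)pyridin-2-yl)oxy on an aromatic carbon gives no change at the digits printed from compound 1 to compound 3 (within the scatter), so these two groups cannot be told apart by this read-out. Nothing available accounts for either step.

The compounds shown leave open whether the step on the amide-type nitrogen follows the loss of the chlorine or the arrival of the triazole ring. From the compounds shown here alone, an unsubstituted phenyl or a 4-aminophenyl on that nitrogen would help separate the two, and the shared core stays untested with any such group.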